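Replacing methyl with fluoro on an aromatic carbon

The compounds below may be only part of what the source reports. "The series", "measured", "known", "first", "only" and "open" are said of these compounds alone.

Measured in a functional assay on cells (Cancer cell lines, Homo sapiens) for inhibition, read by MTT assay, with a stated time of 48 h; a lower number here means a stronger inhibitor, a higher number a weaker inhibitor
compound 1 `O=C(/C=C/c1ccc(Br)cc1)NNC(=O)c1ccc2c(c1)OCCO2` gives 2330 nM
compound 2 `COc1ccccc1/C=C/C(=O)NNC(=O)c1ccc2c(c1)OCCO2` gives 8060 nM
compound 3 `Cc1cccc(/C=C/C(=O)NNC(=O)c2ccc3c(c2)OCCO3)c1` gives 2890 nM

Among these three, the measured step of a 1.2-fold higher number from compound 1 to compound 3 (0.09 log units; within the scatter) separates nothing, while a 2.8-fold lower number from compound 2 to compound 3 (0.45 log units; beyond the scatter) sets the 2-methoxyphenyl member apart. Compound 3 therefore stands level with the 4-bromophenyl member and clear of the 2-methoxyphenyl one.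

Compound 4 `O=C(/C=C/c1cccc(F)c1)NNC(=O)c1ccc2c(c1)OCCO2` carries fluoro in place of methyl on an aromatic carbon, meta to a large group (fluoro in place of methyl on an aromatic carbon). Among the compounds with values here, no measured compound carries fluoro, so no step tests this exchange directly. The nearest evidence comes from exchanges of the same aryl group. One of them, a 1.2-fold higher number from compound 1 to compound 3 (0.09 log units; within the scatter), stayed small, and the larger ones, such as a 3.5-fold higher number from compound 1 to compound 2 (0.54 log units; beyond the scatter), all involve the 2-methoxyphenyl member.

An expected step of a 1.0-fold higher number from compound 3 to compound 4 (0.02 log units; within the scatter) in this assay would therefore stay within the scatter, with no direction favoured. This expectation starts from compound 3 at 2890 nM as its anchor. For compound 4 the estimated value is 3000 nM, with an expected range of 1500 nM to 6000 nM.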

Compound 4, half-maximal inhibitory concentration: 4110 nM
Beside the measured number, compound 4's estimate is 1.4-fold (0.14 log units) below it; the range from low to high includes it.
By their numbers in this assay, from the lowest: compounds 1, 3, 4 and 2 (each within the scatter of the next, the first and the last beyond it).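

In this assay the exchange of methyl for fluoro on this aromatic carbon, meta to a large group, gives a 1.4-fold higher number from compound 3 to compound 4 (0.15 log units; within the scatter) and so produces no readable change at this position. The 3-fluorophenyl member also stays within the scatter of both other aryl variants, with a 1.8-fold higher number from compound 1 to compound 4 (0.25 log units; within the scatter) and a 2.0-fold lower number from compound 2 to compound 4 (0.29 log units; within the scatter) even though the earlier step of a 2.8-fold lower number from compound 2 to compound 3 (0.45 log units; beyond the scatter) lay beyond it, so it does not fall clearly on either side of that earlier divide. No measurement shown here offers an explanation for these values.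

The compounds shown leave open whether an amine, a carboxylic acid or a trifluoromethyl group at this place would give a step beyond the scatter. They also leave open whether fluoro and methyl would stay this close on a ring that also carries a bromo group.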